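The compounds below may be only part of what the source reports. "The series", "measured", "known", "first", "only" and "open" are said of these compounds alone.

Measured so far in a functional assay on BMDM cells (Mus musculus, strain C57BL/6) for inhibition, with a stated time of 2 days; a lower number here means a stronger inhibitor, a higher number a weaker inhibitor: compound 1 `Cc1csc(NC(=O)Cn2cc(-c3ccc([N+](=O)[O-])cc3)nn2)n1` gives 190 nM; compound 2 `Cc1cc(NC(=O)Cn2cc(-c3ccc(C#N)cc3)nn2)no1` gives 9320 nM; compound 3 `O=C(Cn1cc(-c2ccc([N+](=O)[O-])cc2)nn1)Nc1nccs1` gives 1040 nM.

Compound 3 stands second highest of the three numbers. Going by the values given here, the only recorded single-change step, a 5.5-fold higher number from compound 1 to compound 3 (0.74 log units; beyond the scatter), concerns hydrogen in place of methyl on an aromatic carbon, which raised the number. Compound 4 `N#Cc1ccc(-c2cn(CC(=O)Nc3nccs3)nn2)cc1` differs from compound 3 by cyano in place of nitro on an aromatic carbon. Among the compounds with values here, no measured step shows what cyano in place of nitro does on this shared core. Compound 2 carries a cyano group on a different core and has the highest number of the three, but its value and that of compound 3 can only be noted, not read as a step. A weakening of uncertain size is therefore expected; the step estimated here is a 2.9-fold higher number from compound 3 to compound 4 (0.46 log units; beyond the scatter). Compound 4 is expected to give about 3000 nM in this assay, within 800 nM to 12000 nM.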

Compound 4, half-maximal inhibitory concentration: 270 nM
Beside the measured number, compound 4's estimate is 11-fold (1.05 log units) above it; measured number below the stated range.
By their numbers in this assay, from the lowest: compounds 1 and 4 (each within the scatter of the next); then compound 3; then compound 2.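

In this assay, cyano in place of nitro on an aromatic carbon gives a 3.9-fold lower number from compound 3 to compound 4 (0.59 log units; beyond the scatter), so on this shared core a low number does not depend on nitro. With cyano kept, 1,3-thiazol-2-yl in place of 5-methyl-1,2-oxazol-3-yl on the amide-type nitrogen gives a 35-fold lower number from compound 2 to compound 4 (1.54 log units; beyond the scatter). Nothing available explains either step.

Going by these compounds, whether adding methyl to compound 4 would lower its number, as the methyl of compound 1 does relative to compound 3, remains open. So does the effect of an amine or a carboxylic acid in the place of cyano.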